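Nitro added to the phenolic core of compound 3

This account rests on a few compounds, and the source may have more. Where it says the series, first, only, none or still open, it means among the compounds named here.

Working notes on a functional assay on Jurkat cells (Homo sapiens) for antiproliferative activity, read by MTT assay (on this read-out higher numbers stand for weaker inhibition and lower numbers for stronger inhibition), for a small set of arylidene-type compounds sharing one core. Compound 1 `COc1ccc(/C=C2\CCc3cc(OC)c(OC)cc3C2=O)cc1` carries methoxy groups on both rings. In this assay compound 1 reaches only the assay limit, recorded as > 50000 nM, which is a limit and not a number. Compound 2 `COc1cc2c(cc1OC)C(=O)/C(=C/c1cc(C)c([N+](=O)[O-])c(C)c1)C2` keeps two methoxy groups on the core and carries a nitro group flanked by two methyls on the pendant ring; in this assay compound 2 gives 25000 nM. Compound 3 `COc1cc2c(cc1O)C/C(=C\c1cc(C)c(O)c(C)c1)C2=O` carries a free hydroxy group on each ring, and in this assay compound 3 gives 530 nM, the lowest of the two numbers shown, with compound 2 lying beyond the scatter above it. Compounds 2 and 3 differ in more than one place, so no single step can be read from that pair.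

Compound 4 `COc1cc2c(c([N+](=O)[O-])c1O)C/C(=C\c1cc(C)c(O)c(C)c1)C2=O` differs from compound 3 by nitro in place of hydrogen on an aromatic carbon of the core, ortho to the hydroxy group and meta to the methoxy group. Within the data shown here, no measured pair isolates this change. A moderate rise in number, beyond the scatter, is expected. Compound 4 is expected to give 1500 nM in this assay, within a range from 400 nM to 6000 nM. The expected step is a 2.8-fold higher number from compound 3 to compound 4 (0.45 log units; beyond the scatter).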

Compound 4, half-maximal inhibitory concentration: 9300 nM
Compound 4: middle estimate off by 6.2-fold (0.79 log units), on the low side; the whole stated range lies below it.
By their numbers in this assay, from the lowest: compound 3; then compound 4; then compound 2. At a limit, above all of these: compound 1.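

In this assay, the core carbon ortho to a hydroxy group and meta to a methoxy group proves sensitive to substitution: nitro in place of hydrogen there gives an 18-fold higher number from compound 3 to compound 4 (1.24 log units; beyond the scatter), a large step and the first in this series that can be read at a single place. The earlier compounds shown here differ from one another in more than one place, so they could say nothing about this position, whereas here the pendant ring with its hydroxy group and two methyls stays unchanged and the whole step belongs to the core. The step runs between two true numbers, and only compound 1 stands at a limit of the assay, which is not a number: the limit of > 50000 nM in this assay, at which 1 of the 4 values shown sits.

On these data alone, whether the rise in number belongs to nitro itself or would follow any group at this carbon stays open, and an amine, a fluorine atom or a methyl group in the same place would separate these two readings. What each free hydroxy group contributes also remains open, since all other steps among the compounds shown cannot be read.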